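The source may hold more compounds than are shown below. What is called first, only, known or untested is meant among the compounds shown, and "the series" means these compounds.

Compound 2 (`N#Cc1ccc(Cn2cc(COc3ccccc3)nn2)cc1`) was tested in an assay on isolated protein for inhibition of Aromatase (Homo sapiens), read by fluorescence and colorimetric assay, with a stated time of 30 min (on this read-out higher numbers stand for weaker inhibition and lower numbers for stronger inhibition), where compound 2 gave 6090 nM. That is the lower of the two numbers recorded so far. Among the compounds with values here, the only comparison is compound 1 (`c1ccc(OCc2cn(C(c3ccccc3)c3ccccc3)nn2)cc1`), which carries a different group on the triazole nitrogen and gave 31300 nM; the two values lie apart by more than the usual scatter, and no single-point step links them. The next compound is compound 3 (`c1ccc(Cn2cc(COc3ccccc3)nn2)cc1`), which differs from compound 2 by hydrogen in place of cyano on an aromatic carbon. With nothing measured for this exact change, the expectation rests on the two values above. The cyano group is the feature that sets compound 2 apart from the weaker compound 1, so compound 3 is expected to lose ground, a step of a 2.5-fold higher number from compound 2 to compound 3 (0.39 log units; beyond the scatter). For compound 3 an estimate of 15000 nM seems reasonable, within 5000 nM to 45000 nM.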

Compound 3, half-maximal inhibitory concentration: 10600 nM
Beside the measured number, compound 3's estimate is 1.4-fold (0.15 log units) above it, and the stated range covers the measured number.
By their numbers in this assay, from the lowest: compounds 2 and 3 (each within the scatter of the next); then compound 1.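

On an aromatic carbon para to a large group, the step of a 1.7-fold higher number from compound 2 to compound 3 (0.24 log units; within the scatter) shows that hydrogen in place of cyano leaves the number within the scatter, so this position has yet to show a clear response to a change of group. Within the data shown here, the other single-place change, hydrogen in place of phenyl on a saturated chain carbon bound to an aromatic carbon and an aromatic nitrogen, gives a 3.0-fold lower number from compound 1 to compound 3 (0.47 log units; beyond the scatter) and is the only step here beyond the scatter, though a modest one. Nothing given here bears on the reason for either step.

The compounds shown leave open whether a group such as an amine, a methoxy or a carboxylic acid at the para position would move the number beyond the scatter from compound 3. They also leave open how a longer chain in place of that saturated chain carbon would read.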